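From fluoro to trifluoromethyl: a solubility question

The compounds below may be only part of what the source reports. "The series", "measured", "known", "first", "only" and "open" are said of these compounds alone.

compound 1 `Fc1ccc(-c2nc3cnc(Nc4ccccn4)cc3[nH]2)cc1C(F)(F)F` gives < 5000 nM (a limit)
compound 2 `Fc1ccc(Nc2cc3[nH]c(-c4cccc(C(F)(F)F)c4)nc3cn2)nc1` gives < 5000 nM (a limit)
compound 3 `Fc1ccc(Nc2cc3[nH]c(-c4ccc(F)c(F)c4)nc3cn2)nc1` gives < 5000 nM (a limit)

In a physicochemical assay for solubility, using the shake flask method, in phosphate buffer, measured as kinetic solubility, with a stated time of 20 h, at pH 6.5 (a higher number here means a more soluble compound, a lower number a less soluble compound), compound 3 gives < 5000 nM as a limit and not a number. Across the series the readings show the limit of < 5000 nM in this assay, at which 3 of the 3 values shown sit, so no exact value is known yet. Compound 4 `Fc1ccc(Nc2cc3[nH]c(-c4ccc(F)c(C(F)(F)F)c4)nc3cn2)nc1` has trifluoromethyl in place of fluoro on an aromatic carbon and is otherwise the same as compound 3. Going by the values given here, no measured step shows what this change does. Compound 1 carries trifluoromethyl and has the limit < 5000 nM in this assay so no change beyond the scatter is expected. The estimate is a step that the limit leaves unreadable from compound 3 to compound 4 within the usual scatter. For compound 4 the expected value is 3000 nM with an estimated range of 1000 nM to 5000 nM and another limit is likely.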

Compound 4, solubility: < 5000 nM
Compound 4: only a limit was reported; the forecaster's own chance of this, stated with the estimate: 85%; the middle value does not contradict the limit.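

No step can be read between compound 4 and compound 1, compound 2 or compound 3, because each reading is a limit and not a number: the limit of < 5000 nM in this assay, at which 4 of the 4 values shown sit.

From the compounds shown here alone, the exact solubility of all four compounds stays open, as does what trifluoromethyl in place of fluoro on an aromatic carbon does to it.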